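Swapping a Ring Hydrogen for Trifluoromethoxy on the Core

A few compounds are considered here, and "the series" means these few. Any claim that something is new, unique, unknown or untested is made for them only; others in the source may bear on it.

Of the compounds shown here, two share one core and have been tested in a functional assay on ileum (Cavia porcellus) for antagonist activity at cysteinyl leukotriene receptor (Homo sapiens); a higher number here means a weaker inhibitor, a lower number a stronger inhibitor. Compound 1 `CCC(CC)(CC(=O)Nc1cccc(OCc2ccc3ccc(Br)cc3n2)c1)C(=O)O` carries a bromo group on the fused ring and gives 4 nM. Compound 2 `CCC(CC)(CC(=O)Nc1cccc(OCc2ccc3ccccc3n2)c1)C(=O)O` has a hydrogen in that place and gives 0.9 nM. Among the compounds with values here, compound 2 thus stands at the lowest of the two numbers, and the only step in the set, a 4.4-fold lower number from compound 1 to compound 2 (0.65 log units; beyond the scatter), shows that removing the bromo group was matched by a modestly lower number.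

Compound 3 `CCC(CC)(CC(=O)Nc1cccc(OCc2ccc3ccc(OC(F)(F)F)cc3n2)c1)C(=O)O` is the next question. Relative to compound 2, the change is trifluoromethoxy in place of hydrogen on an aromatic carbon. Within the data shown here, the site is the same one at which compound 1 carries its bromo group, so the step from compound 1 to compound 2 is the only measured step that bears on it. Because that step, a 4.4-fold lower number from compound 1 to compound 2 (0.65 log units; beyond the scatter), went toward a lower number when a substituent was taken away, putting a substituent back in is expected to move the number modestly upward, an expected step of a 3.3-fold higher number from compound 2 to compound 3 (0.52 log units; beyond the scatter). Compound 3 is therefore estimated at 3 nM, with a range from 1 nM to 10 nM.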

Compound 3, half-maximal inhibitory concentration: 9 nM
The estimate for compound 3 lay 3.0-fold (0.48 log units) below the measured number; low and high end bracket the measured number.
By their numbers in this assay, from the lowest: compound 2; then compound 1; then compound 3.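

Placing trifluoromethoxy on this aromatic carbon in this assay gives a 10-fold higher number from compound 2 to compound 3 (1.00 log units; beyond the scatter), so hydrogen now gives a lower number than both substituents shown at this site, not just bromo. The two substituents also differ from each other: trifluoromethoxy in place of bromo gives a 2.3-fold higher number from compound 1 to compound 3 (0.35 log units; beyond the scatter) here, so the size of the rise depends on which group enters, not only on whether a substituent is present. Nothing available here explains why the numbers fall in this order.

With only bromo and trifluoromethoxy to compare with hydrogen, the compounds shown leave open how other groups would behave at this carbon, such as fluoro, methyl, a hydroxy group or an amine. They also leave open whether bromo and trifluoromethoxy would keep the same order on another carbon of this ring, since all three compounds differ at this one place only.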